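This account rests on a few compounds, and the source may have more. Where it says the series, first, only, none or still open, it means among the compounds named here.

Measured in a functional assay on DU-145 cells (Homo sapiens) for antiproliferative activity, read by MTT assay, with a stated time of 48 h; a lower number here means a stronger inhibitor, a higher number a weaker inhibitor:
- compound 1 `C/C(=C\CC/C(C)=C/CC[C@@H]1[C@@]2(C)CCC(=O)C(C)(C)[C@H]2CC[C@@]1(C)O)CC/C=C(\C)C(=O)OCc1cn(-c2ccc(F)cc2)nn1`: > 150000 nM
- compound 2 `C/C(=C\CC/C(C)=C/CC[C@@H]1[C@@]2(C)CCC(=O)C(C)(C)[C@H]2CC[C@@]1(C)O)CC/C=C(\C)C(=O)OCc1cn(-c2cccc([N+](=O)[O-])c2)nn1`: > 150000 nM

Each entry is a limit of the assay and not a number. Compound 2 stands at the limit of > 150000 nM in this assay, at which 2 of the 2 values shown sit, so no exact potency is known for it. Compound 3 `C/C(=C\CC/C(C)=C/CC[C@@H]1[C@@]2(C)CCC(=O)C(C)(C)[C@H]2CC[C@@]1(C)O)CC/C=C(\C)C(=O)OCc1cn(-c2cccc(C)c2)nn1` has methyl in place of nitro on an aromatic carbon. Among the measured compounds shown here, the only measured step that bears on this change is a step that the two limits leave unreadable from compound 1 to compound 2, where 3-nitrophenyl replaces 4-fluorophenyl on an aromatic nitrogen. That step offers neither a size nor a direction to carry over, so no step beyond the scatter is expected in this assay. The estimated change is a step that the limit leaves unreadable from compound 2 to compound 3, and it is likely that the assay will again report only a limit. For compound 3 the expected value is 180000 nM, with an estimated range of 60000 nM to 400000 nM.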

Compound 3, half-maximal inhibitory concentration: 137000 nM
Beside the measured number, compound 3's estimate is 1.3-fold (0.12 log units) above it, within the range that was stated.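

In this assay, among the compounds shown here, compound 3 gives 137000 nM, the first exact number in this set, so a 3-methylphenyl group brings the series just within what the assay can measure. Methyl in place of nitro gives an at least 1.0-fold lower number from compound 2 to compound 3 (0.03 log units; that floor lies within the scatter), and 3-methylphenyl in place of 4-fluorophenyl gives an at least 1.0-fold lower number from compound 1 to compound 3 (0.03 log units; that floor lies within the scatter), so neither change can be called a real gain, although the true steps could be larger. Compound 1 and compound 2 remain limits, and the step between them cannot be read: the limit of > 150000 nM in this assay, at which 2 of the 3 values shown sit.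

The compounds shown leave open whether methyl itself matters at this place on the phenyl ring or whether any other group would read the same. An amine, a carboxylic acid or a longer chain such as ethyl there could show how far the number can move.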